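Compound 2 and its mirror image

The source may report more compounds than this note shows. Statements on the series, on what has been measured and on what is new or still open speak of the compounds shown alone.

Values in a physicochemical assay for lipophilicity (a higher number here means a more lipophilic compound, a lower number a more polar compound), follow.
- compound 1 `CS(=O)(=O)Cc1cc(C2=CCOCC2)nc(-c2cccc(O)c2)n1` gives 3.3
- compound 2 `CS(=O)(=O)Cc1cc([C@]23CCOC[C@H]2C3)nc(-c2cccc(O)c2)n1` gives 3.7

Of these two, compound 2 stands higher, at 3.7. Among the compounds with values here, the only measured step is a number 0.40 log units higher from compound 1 to compound 2 (beyond the scatter), but it replaces one group with another and so offers no direct guide here. Compound 3 `CS(=O)(=O)Cc1cc([C@@]23CCOC[C@@H]2C3)nc(-c2cccc(O)c2)n1` differs from compound 2 as follows: the two compounds have the same atoms and bonds and differ only in configuration as drawn: 2 of 2 stereo elements differ (all stereocentres are inverted: mirror images); a stereocentre at a saturated ring carbon is drawn R in compound 2 and S in compound 3; a stereocentre at a saturated ring carbon is drawn S in compound 2 and R in compound 3. Within the data shown here, no step of this kind has been measured, and no change beyond the scatter is expected in this assay. The expected step is no change at the digits printed from compound 2 to compound 3 (within the scatter). For compound 3 the estimated value is 3.7, within an expected range of 3.4 to 4.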

Compound 3, partition coefficient: 3.7
The estimate for compound 3 equals the measured number at the digits printed; measured number inside the range.
By their numbers in this assay, from the lowest: compound 1; then compounds 2 and 3 (each within the scatter of the next).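

Inverting both stereocentres gives, in this assay, no change at the digits printed from compound 2 to compound 3 (within the scatter), so the configuration of this group does not register in this read-out, and the reason lies in the structures: the fact that compounds 2 and 3 differ only in the configuration as drawn. The gain over the group with a single six-membered ring is thus not tied to one mirror image (a number 0.40 log units higher from compound 1 to compound 3 (beyond the scatter)). It matches the step already seen with the other mirror image (a number 0.40 log units higher from compound 1 to compound 2 (beyond the scatter)).

Only this assay is shown, so whether the two mirror images part in any biological measurement stays open. So does the number that a morpholine or a longer alkyl chain would give on this aromatic carbon.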